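Aryl ether series: cyano in place of bromo

A few compounds are considered here, and "the series" means these few. Any claim that something is new, unique, unknown or untested is made for them only; others in the source may bear on it.

Within the data shown here, compound 2 `O=c1ccoc2ccc(OCc3ccc(Br)cc3)cc12` gives 95 nM in an assay on microsomes for inhibition of Amine oxidase [flavin-containing] A (Homo sapiens), read by fluorescence and spectrophotometry, with a stated time of 20 min (on this read-out lower numbers stand for stronger inhibition and higher numbers for weaker inhibition), the lowest of the two numbers measured so far; compound 1 `O=c1ccoc2ccc(OCCc3ccccc3)cc12` gives 3120 nM, a gap beyond the scatter. Compound 3 `N#Cc1ccc(COc2ccc3occc(=O)c3c2)cc1` differs from compound 2 by cyano in place of bromo on an aromatic carbon, para to a large group. Among the measured compounds shown here, no step between measured compounds covers this change, so the expectation rests on compound 2 alone. A modest step toward weaker inhibition, a 2.1-fold higher number from compound 2 to compound 3 (0.32 log units; beyond the scatter), is expected, likely near the scatter. Compound 3 is estimated at 200 nM, with a range from 50 nM to 800 nM.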

Compound 3, half-maximal inhibitory concentration: 175 nM
Compound 3: the middle estimate sits 1.1-fold (0.06 log units) above what was measured, within the range that was stated.
By their numbers in this assay, from the lowest: compounds 2 and 3 (each within the scatter of the next); then compound 1.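

Cyano in place of bromo gives a 1.8-fold higher number from compound 2 to compound 3 (0.27 log units; within the scatter) and so leaves compound 2 and compound 3 indistinguishable on this read-out. This position, para to a large group, therefore accepts either bromo or cyano, even though cyano brings a triple bond, a second heavy atom and a hydrogen-bond acceptor. No measurement available here explains why the two groups read alike.

As far as these compounds go, whether this tolerance extends to an amine or a carboxylic acid at the same position remains open. The compounds shown also do not tell how a methoxy group or an unsubstituted ring carbon would read there.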